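Swapping Hydroxy for Chloro on a Shared Core

This account rests on a few compounds, and the source may have more. Where it says the series, first, only, none or still open, it means among the compounds named here.

Of the compounds shown here, three have been measured in a functional assay on SW982 cells (Homo sapiens) for inhibition, read by MTT assay, with a stated time of 72 h; a lower number here means a stronger inhibitor, a higher number a weaker inhibitor. Compound 1, `COc1cc(OC)c(OC)cc1/C=C/C(=O)c1ccc(C)cc1`, gives 81100 nM in this assay. Compound 3, `COc1cc(C(=O)/C=C/c2cc(OC)c(OC)cc2OC)ccc1O`, returns only a limit of the assay, > 150000 nM. Compound 2, `COc1cc(OC)c(-c2cc(=O)c3cc(O)ccc3o2)cc1OC`, likewise returns only a limit of the assay, > 150000 nM. Its standing among the three is therefore known only as sitting at that limit, which is the limit of > 150000 nM in this assay, at which 2 of the 3 values shown sit; no number for compound 2 has been recorded.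

Compound 4, `COc1cc(OC)c(-c2cc(=O)c3cc(Cl)ccc3o2)cc1OC`, differs from compound 2 by a single change: chloro in place of hydroxy on an aromatic carbon. Among the measured compounds shown here, no two measured compounds in this set differ in only one place, so this change has no measured counterpart here, and its size must be judged without one. With compound 2 itself at the limit of the assay, the step from compound 2 to compound 4 is expected to be small or none beyond the scatter, a number no higher from compound 2 to compound 4 (the limit leaves the size open), in this assay. Compound 4 is accordingly estimated at 150000 nM, with a range from 50000 nM to 400000 nM, and a further limit reading is considered likely.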

Compound 4, half-maximal inhibitory concentration: > 150000 nM
Compound 4 was reported as a limit (the forecaster's own chance of this, stated with the estimate: 60%); the middle value lies on the limit itself.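

Compound 2 and compound 4 both return only a limit in this assay, so the step between them, chloro in place of hydroxy on an aromatic carbon, cannot be read: the limit of > 150000 nM in this assay, at which 3 of the 4 values shown sit.

The compounds shown leave open whether this swap changes inhibition at all in this assay.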